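Urea-to-amide step in a pyrazole series at low concentration

This account rests on a few compounds, and the source may have more. Where it says the series, first, only, none or still open, it means among the compounds named here.

Measured so far:
compound 1 `COc1cc(Cl)cc(-c2nn(-c3cccc(NC(=O)Nc4ccc(Cl)c(Cl)c4)c3)cc2-c2ccncc2)c1`: 97%
compound 2 `COc1cc(Cl)cc(-c2nn(-c3cccc(NC(=O)Nc4cccc(C(F)(F)F)c4)c3)cc2-c2ccncc2)c1`: 98%

In a functional assay on CCRF-CEM cells (Homo sapiens) for inhibition, read by sulforhodamine B assay, with a stated time of 48 h, tested at 0.01 uM (a higher number here means a weaker effect of the compound at the concentration tested, a lower number a stronger effect), compound 1 gives 97% and compound 2 gives 98%. Among the measured compounds shown here, the only measured step is a number 1 percentage points higher from compound 1 to compound 2 (within the scatter), so compound 2 stands together with compound 1, the two values within the scatter of each other and both close to no inhibition at this concentration.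

Compound 3 `COc1cc(Cl)cc(-c2nn(-c3cccc(NC(=O)c4cccc(C(F)(F)F)c4)c3)cc2-c2ccncc2)c1` is not yet measured. It differs from compound 2 by 3-(trifluoromethyl)phenyl in place of (3-(trifluoromethyl)phenyl)amino on a carbonyl carbon. For the measured compounds named here, no measured step touches the carbonyl carbon or removes an amino group; the one step on record, between compound 1 and compound 2, changes only the aryl group on the amide-type nitrogen and is within the scatter. There is therefore no measured basis for expecting a shift beyond the scatter in this assay.

For compound 3 the expected value is 96%, with a range of 86% to 102%. This estimate means a step of a number 2 percentage points lower from compound 2 to compound 3 (within the scatter), which is expected to stay within the scatter.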

Compound 3, a percentage reported as activity, at one concentration (the size of the read-out at that concentration, not a potency): 96%
Compound 3: the middle estimate sits on the measured number at the digits printed; low and high end bracket the measured number.
By their numbers in this assay, from the lowest: compounds 3, 1 and 2 (each within the scatter of the next).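

In this assay, the change on the carbonyl carbon, 3-(trifluoromethyl)phenyl in place of (3-(trifluoromethyl)phenyl)amino, gives a number 2 percentage points lower from compound 2 to compound 3 (within the scatter), so this position now has a measured step of its own, and at this concentration the urea and the amide cannot be told apart. The change that also swaps the aryl group, 3-(trifluoromethyl)phenyl in place of (3,4-dichlorophenyl)amino, reads the same way, with a number 1 percentage points lower from compound 1 to compound 3 (within the scatter). Nothing on hand accounts for this result.

The compounds shown leave open whether any other group on the carbonyl carbon, such as an amine or a carboxylic acid, would move the number in this assay. They also leave open whether urea and amide would separate at a concentration where the series gives clear inhibition.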